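Acyl chain lengthening in the isopropylphenyl sulfonate anilides

The source may report more compounds than this note shows. Statements on the series, on what has been measured and on what is new or still open speak of the compounds shown alone.

Compound 1 `CC(=O)Nc1cccc(S(=O)(=O)Oc2ccccc2C(C)C)c1`: 21000 nM in a functional assay on HT-1080 cells (Homo sapiens) for antiproliferative activity, read by sulforhodamine B assay, with a stated time of 48 h; a lower number here means a stronger inhibitor, a higher number a weaker inhibitor
Compound 2 `CCC(=O)Nc1cccc(S(=O)(=O)Oc2ccccc2C(C)C)c1`: 12000 nM in this assay

Within the data shown here, compound 2 and compound 1 lie within the scatter of each other; the single step, a 1.8-fold lower number from compound 1 to compound 2 (0.24 log units; within the scatter), grew the acyl chain by one carbon without a clear effect. Compound 3 `CCCC(=O)Nc1cccc(S(=O)(=O)Oc2ccccc2C(C)C)c1` repeats that move: methyl in place of hydrogen on a saturated chain carbon, two bonds along the chain from a carbonyl carbon, the propanoyl becoming propylcarbonyl. Among the measured compounds shown here, only the step from compound 1 to compound 2 bears on it, and it was small, so no shift beyond the scatter is expected in this assay, at most a slight drift to a lower number. Compound 3 is estimated at 9000 nM, range 4000 nM to 20000 nM. The expected step is a 1.3-fold lower number from compound 2 to compound 3 (0.12 log units; within the scatter).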

Compound 3, half-maximal inhibitory concentration: 15000 nM
Compound 3: middle estimate off by 1.7-fold (0.22 log units), on the low side; the measured number falls inside the stated range.
By their numbers in this assay, from the lowest: compounds 2, 3 and 1 (each within the scatter of the next).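

Methyl in place of hydrogen, two bonds along the chain from a carbonyl carbon, gives a 1.3-fold higher number from compound 2 to compound 3 (0.10 log units; within the scatter) in this assay, so this carbon, like the one before it, produces no step beyond the scatter. Ethyl in place of hydrogen on the chain carbon bound to a carbonyl carbon gives a 1.4-fold lower number from compound 1 to compound 3 (0.15 log units; within the scatter), so the two carbons taken together show no trend with chain length across these three compounds. No supporting evidence bears on this result.

Going by these compounds, whether a longer chain, or an amine or carboxylic acid at the chain end, would move the number beyond the scatter remains open.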